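Dichloro purines on a breast cancer cell line

This account rests on a few compounds, and the source may have more. Where it says the series, first, only, none or still open, it means among the compounds named here.

Measured so far:
compound 1 `ClCc1ccccc1Cn1cnc2c(Cl)nc(Cl)nc21` gives 6450 nM
compound 2 `ClCc1ccccc1Cn1cnc2c(Cl)ncnc21` gives 36300 nM
compound 3 `ClCc1cccc(Cn2cnc3c(Cl)ncnc32)c1` gives 6450 nM

These three compounds were tested in a functional assay on MDA-MB-435 cells (Homo sapiens) for cytotoxicity, read by sulforhodamine B assay, with a stated time of 48 h; a lower number here means that less compound is tolerated, a higher number that more compound is tolerated. Compound 1 and compound 2 share a core; the change between them is chloro in place of hydrogen on an aromatic carbon. That change gave a 5.6-fold lower number from compound 2 to compound 1 (0.75 log units; beyond the scatter). Compound 3 has the same atoms as compound 2 joined differently; the difference between the two cores is not broken down here. In this assay compound 3 stands level with compound 1 within the scatter, and the two together give the lowest numbers of the three.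

Compound 4 `ClCc1cccc(Cn2cnc3c(Cl)nc(Cl)nc32)c1` has not yet been measured. It differs from compound 3 by chloro in place of hydrogen on an aromatic carbon, the same change in the same surroundings as from compound 2 to compound 1. Because that earlier step was a 5.6-fold lower number from compound 2 to compound 1 (0.75 log units; beyond the scatter), a step of similar size is expected here, namely a 4.3-fold lower number from compound 3 to compound 4 (0.63 log units; beyond the scatter). On that basis compound 4 is estimated at 1500 nM, expected between 500 nM and 5000 nM.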

Compound 4, concentration lethal to 50% of the cells: 6310 nM
Compound 4: middle estimate off by 4.2-fold (0.62 log units), on the low side; measured number outside the range, above it.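

In this assay, placing a chloro group on the core of compound 3, on the aromatic carbon between two ring nitrogen atoms, gives a 1.0-fold lower number from compound 3 to compound 4 (0.01 log units; within the scatter) and so no real change. The step therefore did not carry over from one core to the other, and the two cores, which hold the same atoms joined differently, respond to the same change by clearly different amounts: the same change on two cores in this assay, a 5.6-fold lower number (0.75 log units; beyond the scatter) from compound 2 to compound 1 and a 1.0-fold lower number (0.01 log units; within the scatter) from compound 3 to compound 4, 5.5-fold (0.74 log units) apart, beyond the scatter of two such steps. This shows that, in these two pairs, the size of the step depends on the core, but two pairs cannot show which feature of the cores is responsible, or how the change would behave on a further core.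

On these data alone, only hydrogen and chloro appear at this position, so it remains open whether an amine or a longer chain there would separate the two cores in the same way. As far as these compounds go, it also remains open whether such a group would give a step on the core of compound 3 at all.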